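The source may hold more compounds than are shown below. What is called first, only, known or untested is meant among the compounds shown, and "the series" means these compounds.

The measured compounds in a functional assay on ileum (strain Hartley) for agonist activity at 5-hydroxytryptamine receptor 3A (Cavia porcellus); on this read-out higher numbers stand for higher potency (the scale is a negative logarithm) and lower numbers for lower potency:

compound 1, `Cc1cc(Cl)c2oc(N3CCN(C)CC3)nc2c1`: 6.22
compound 2, `CN1CCN(c2nc3cc(F)ccc3o2)CC1`: 5.57
compound 3, `Cc1cc(C)c2oc(N3CCN(C)CC3)nc2c1`: 6.32

Compound 1 stands second highest of these three numbers. Compound 3 sits closest to it, and the step of a number 0.10 log units higher from compound 1 to compound 3 (within the scatter) lies within the scatter. Compound 2 gives the lowest value, beyond the scatter from compound 1.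

Compound 4, `CN1CCN(c2nc3cc(Cl)cc(Cl)c3o2)CC1`, is compound 1 with one change: chloro in place of methyl on an aromatic carbon. Among the measured compounds shown here, the only measured step that bears on this is the exchange of chloro for methyl from compound 1 to compound 3, which changed the read-out within the scatter. The reverse exchange on the shared core is therefore expected to be similarly flat, so the step of a number 0.02 log units lower from compound 1 to compound 4 (within the scatter) is expected to stay within the scatter. Compound 4 is estimated at 6.2, between 5.7 and 6.7.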

Compound 4, negative logarithm of the half-maximal effective concentration: 6.51
Compound 4: middle estimate off by 0.31 log units, on the low side, and the stated range covers the measured number.
By their numbers in this assay, from the lowest: compound 2; then compounds 1, 3 and 4 (each within the scatter of the next).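

In this assay the exchange at this position gives a number 0.29 log units higher from compound 1 to compound 4 (within the scatter), so chloro and methyl on this aromatic carbon cannot be told apart on this read-out. The earlier step, a number 0.10 log units higher from compound 1 to compound 3 (within the scatter), exchanged the other group, so both ring groups have now been swapped between chloro and methyl without leaving the scatter. Nothing measured here offers an explanation for this result. Going by these compounds, what stays open is whether a group of a different kind at this position, such as methoxy, an amine or a carboxylic acid, would move the read-out beyond the scatter.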